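Dropping the Fluorine: From Compound 2 to Compound 3

The source may report more compounds than this note shows. Statements on the series, on what has been measured and on what is new or still open speak of the compounds shown alone.

Of the compounds shown here, two have been tested in a functional assay on RPMI-8226 cells (Homo sapiens) for inhibition; on this read-out lower numbers stand for stronger inhibition and higher numbers for weaker inhibition. Compound 1 `N#CC1CN1C(=O)Nc1ccc(Cl)c(Cl)c1` gives 2700 nM. Compound 2 `N#CC1CN1C(=O)Nc1ccc(F)cc1` gives 5900 nM, the higher of the two numbers, and the gap to compound 1 is beyond the usual scatter. Compound 3 `N#CC1CN1C(=O)Nc1ccccc1` differs from compound 2 only by hydrogen in place of fluoro on an aromatic carbon. For the measured compounds named here, no such step has been measured here, so only a small step is expected, if any, leaning toward a weaker result: the estimated step from compound 2 to compound 3 in this assay is a 1.2-fold higher number from compound 2 to compound 3 (0.07 log units; within the scatter). Compound 3 is therefore expected to give about 7000 nM, within a range from 3000 nM to 16000 nM.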

Compound 3, half-maximal inhibitory concentration: 8000 nM
Beside the measured number, compound 3's estimate is 1.1-fold (0.06 log units) below it; low and high end bracket the measured number.
By their numbers in this assay, from the lowest: compound 1; then compounds 2 and 3 (each within the scatter of the next).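

With hydrogen in place of fluoro on this aromatic carbon, this assay shows a 1.4-fold higher number from compound 2 to compound 3 (0.13 log units; within the scatter) and so does not separate the two groups at this position. Fluoro is therefore not required here for a number in this range, and this small change leaves the read-out within its normal noise. Nothing available explains this result.

Going by these compounds, it remains open whether a larger group on the same carbon, such as an amine, a carboxylic acid or a longer chain, would give a step beyond the scatter.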